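The source may report more compounds than this note shows. Statements on the series, on what has been measured and on what is new or still open speak of the compounds shown alone.

Values in a functional assay on HUVEC cells (Homo sapiens) for inhibition; on this read-out lower numbers stand for stronger inhibition and higher numbers for weaker inhibition:
- compound 1 `CN(c1ccc(NC(=O)Nc2cc(C(F)(F)F)ccc2F)cc1)c1ccnc(Nc2ccc(S(N)(=O)=O)cc2)n1`: 8 nM
- compound 2 `CC(=O)c1ccc(NC(=O)Nc2ccc(N(C)c3ccnc(Nc4cccc(CS(C)(=O)=O)c4)n3)cc2)cc1`: 2 nM
- compound 3 `CN(c1ccc(NC(=O)Nc2ccc(OC(F)(F)F)cc2)cc1)c1ccnc(Nc2cccc(CS(C)(=O)=O)c2)n1`: 7 nM

Compound 3 at 7 nM lies within the scatter of compound 1, and compound 2 lies lower, beyond the scatter.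

Compound 4 `CN(c1ccc(NC(=O)Nc2ccc(OC(F)(F)F)cc2)cc1)c1ccnc(Nc2ccc(S(N)(=O)=O)cc2)n1` has not yet been measured. It carries 4-sulfamoylphenyl in place of 3-((methylsulfonyl)methyl)phenyl on a nitrogen on an aromatic ring.

Among the compounds with values here, no measured step isolates this change. The only one available, a 3.5-fold higher number from compound 2 to compound 3 (0.54 log units; beyond the scatter), concerns a different place and gives only a sense of how large a single change can be in this small set. The closer evidence is compound 1, which already carries 4-sulfamoylphenyl and gives 8 nM, a value within the scatter of that of compound 3. No shift beyond the scatter is therefore expected in this assay.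

The expected change is no change at the digits printed from compound 3 to compound 4 (within the scatter).

For compound 4 the estimated value is 7 nM, with an expected range of 3 nM to 20 nM.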

Compound 4, half-maximal inhibitory concentration: 37 nM
The estimate for compound 4 lay 5.3-fold (0.72 log units) below the measured number, outside the stated range (above it).
By their numbers in this assay, from the lowest: compound 2; then compounds 3 and 1 (each within the scatter of the next); then compound 4.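

In this assay, within the data shown here, the position on the nitrogen on an aromatic ring responds to this change: 4-sulfamoylphenyl in place of 3-((methylsulfonyl)methyl)phenyl gives a 5.3-fold higher number from compound 3 to compound 4 (0.72 log units; beyond the scatter) as the first measured step at this place. With 4-sulfamoylphenyl held fixed, 4-(trifluoromethoxy)phenyl in place of 2-fluoro-5-(trifluoromethyl)phenyl on an amide-type nitrogen gives a 4.6-fold higher number from compound 1 to compound 4 (0.67 log units; beyond the scatter), so the value of compound 1 did not carry over to the partner in compound 4. No measurement in hand explains either step.

Open, from the compounds shown here alone, is whether the change of 3-((methylsulfonyl)methyl)phenyl to 4-sulfamoylphenyl gives a step of similar size alongside 2-fluoro-5-(trifluoromethyl)phenyl or the acetyl group of compound 2. Also open, going by these compounds, is how a carboxylic acid or an amine on this aromatic ring, in place of either sulfur-bearing group, would read in this assay on the shared core.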